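Swapping acetyl for propyl on an aromatic nitrogen

The source may report more compounds than this note shows. Statements on the series, on what has been measured and on what is new or still open speak of the compounds shown alone.

In a functional assay on the whole organism with Mus musculus as the target (a higher number here means that more compound is needed for the effect, a lower number that less compound is needed), compound 1 `Cc1c(C)c2c(c(C)c1N)CC(C)(CSc1ccc(F)cc1)O2` gives 17.9 mg/kg and compound 2 `Cc1c(C)c2c(c(C)c1N)CC(C)(CCN1CCCCC1)O2` gives 18.4 mg/kg, two values within the usual scatter of each other. Compound 3 `CC(=O)Nc1c(C)c(C)c2c(c1C)CC(C)(C)O2` gives only a limit, > 100 mg/kg. Compound 4 `CCCNc1c(C)c(C)c2c(c1C)CC(C)(C)O2` has propyl in place of acetyl on a nitrogen on an aromatic ring. Going by the values given here, no measured pair shows this change directly, so the size of the step is a judgement. Neither compound 1 nor compound 2 has acetyl on that nitrogen, and compound 2 gives 18.4 mg/kg. A fall in the dose needed, beyond the scatter, is expected for an at least 2.5-fold lower number from compound 3 to compound 4 (0.39 log units; beyond the scatter). For compound 4 the estimated value is 40 mg/kg, with an expected range of 15 mg/kg to 90 mg/kg.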

Compound 4, dose for 50% inhibition: 51.1 mg/kg
For compound 4 the middle estimate is 1.3-fold (0.11 log units) below the measured one; the range from low to high includes it.
By their numbers in this assay, from the lowest: compounds 1 and 2 (each within the scatter of the next); then compound 4. At a limit, above all of these: compound 3.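

In this assay, swapping acetamido for propylamino on this nitrogen gives an at least 1.9-fold lower number from compound 3 to compound 4 (0.29 log units; that floor lies within the scatter). Going by these compounds alone, this is the first direct look at the nitrogen, and a measured number now stands where acetamido left none, though the true step may be larger than this floor. The number for compound 3 is a limit, not a value: the limit of > 100 mg/kg in this assay, at which 1 of the 4 values shown sits.

Going by these compounds, whether the lower number comes from losing the carbonyl or from gaining the propyl chain stays open. So does how a methyl group or a butyl chain on this nitrogen would compare.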